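The source may hold more compounds than are shown below. What is called first, only, known or untested is meant among the compounds shown, and "the series" means these compounds.

In an assay on cells for inhibition of histone-lysine N-methyltransferase EZH2 (Homo sapiens), read by ELISA, with a stated time of 72 h (a lower number here means a stronger inhibitor, a higher number a weaker inhibitor), compound 3 `COc1cc(C)[nH]c(=O)c1CN1CCc2c(Cl)cc(-c3c(C)noc3C)c(Cl)c2C1=O` gives 8 nM, the lowest of the two single numbers recorded so far. Compound 1 `Cc1cc(C)c(CN2CCc3c(Cl)cc([C@H](CO)[C@H]4CCOC4)c(Cl)c3C2=O)c(=O)[nH]1` gives 10 nM in this assay, and the two values lie within the usual scatter of each other. Compound 2 `COC(c1cc(Cl)c2c(c1Cl)C(=O)N(Cc1c(C)cc(C)[nH]c1=O)CC2)C1CCOC1` has several entries in this assay, 1100 nM; 494 nM; 47 nM; 7 nM (4 entries), which spread widely, as the repeated measurements show (the several entries of compound 2 in this assay, 1100 nM; 494 nM; 47 nM; 7 nM (4 entries)). Compound 4 `COc1cc(C)[nH]c(=O)c1CN1CCc2c(Cl)cc([C@H](O)C3COC3)c(Cl)c2C1=O` has not yet been measured. It differs from compound 3 in one place: a group of 6 heavy atoms (4 carbon, 2 oxygen; one four-membered non-aromatic ring with 1 hetero atom) in place of a group of 7 heavy atoms (5 carbon, 1 nitrogen, 1 oxygen; one five-membered aromatic ring with 2 hetero atoms), on an aromatic carbon. Within the data shown here, no step between two measured compounds matches this change, so the expectation rests on the whole set. Compound 1, which also carries a hydroxyl-bearing non-aromatic group on that carbon, gives 10 nM. Compound 4 is therefore expected to give a somewhat higher number, a modest step of a 3.1-fold higher number from compound 3 to compound 4 (0.49 log units; beyond the scatter) that may not exceed the scatter. The estimate for compound 4 is 25 nM, within a range from 6 nM to 120 nM.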

Compound 4, half-maximal inhibitory concentration in the histone-lysine N-methyltransferase EZH2 assay: 99 nM
Estimate against measurement, compound 4: 4.0-fold (0.60 log units) below; low and high end bracket the measured number.
By their numbers in the histone-lysine N-methyltransferase EZH2 assay, from the lowest: compounds 3 and 1 (each within the scatter of the next); then compound 4.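

Exchanging the 3,5-dimethyl-1,2-oxazol-4-yl group for the hydroxyl-bearing four-membered ring on this aromatic carbon gives, in the histone-lysine N-methyltransferase EZH2 assay, a 12-fold higher number from compound 3 to compound 4 (1.09 log units; beyond the scatter). Among these compounds, this is the only measured step at this position, and it shows that the two groups are not interchangeable here. In a physicochemical assay for lipophilicity, at pH 7.4 (on this read-out lower numbers stand for lower lipophilicity and higher numbers for higher lipophilicity), compound 3 gives 2.7 and compound 4 gives 1.4 on the same read-out. The same change also lowers the measured lipophilicity: the measured distribution coefficient of compound 3, 2.7, and of compound 4, 1.4, a number 1.30 log units lower (beyond the scatter)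

This single pair cannot separate the loss of inhibition from the drop in lipophilicity. On these data alone, how an amine or a carboxylic acid on this carbon would behave also remains open.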